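Aryl amide change from compound 2 to compound 3

The compounds below may be only part of what the source reports. "The series", "measured", "known", "first", "only" and "open" are said of these compounds alone.

Compound 1 `Cc1cccc(NC(=O)CN2CCC(c3ccccc3C#N)CC2)c1` and compound 2 `O=C(NCN1CCC(c2cccc[n+]2[O-])CC1)c1cc(Cl)cc(Cl)c1` have been run in a functional assay on HEK293 cells for agonist activity at D(4) dopamine receptor (Homo sapiens), read by FLIPR; a lower number here means a smaller maximal response, a higher number a larger maximal response. Compound 1 reaches 71%, and compound 2 reaches 64%, the lowest of the two numbers, with compound 1 lying within the scatter of it. Compound 3 `O=C(NCN1CCC(c2cccc[n+]2[O-])CC1)c1ccc(F)c(Cl)c1` is not yet measured. It differs from compound 2 in one place: 3-chloro-4-fluorophenyl in place of 3,5-dichlorophenyl on a carbonyl carbon. Among the compounds with values here, no measured pair isolates this change, so the step in this assay is expected to stay within the scatter, in no set direction. Compound 3 is expected to give 64%, in a range from 50% to 78%. The expected step is no change at the digits printed from compound 2 to compound 3 (within the scatter).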

Compound 3, largest response reached (reported as efficacy), in percent of the reference or control that the assay uses: 67%
For compound 3 the middle estimate is 3 percentage points below the measured one; measured number inside the range.
By their numbers in this assay, from the lowest: compounds 2, 3 and 1 (each within the scatter of the next).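

In this assay, 3-chloro-4-fluorophenyl in place of 3,5-dichlorophenyl on a carbonyl carbon gives a number 3 percentage points higher from compound 2 to compound 3 (within the scatter), so the two aryl groups cannot be told apart at this position. Within the data shown here, this is the first pair that isolates a change in one place, and it shows that this exchange of one chlorine for one fluorine, with the ring pattern also altered, leaves the maximal response within the scatter. No evidence bearing on this result is at hand. Open, as far as these compounds go, is whether a carboxylic acid or an amine on this aryl ring would give a step beyond the scatter.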